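Acid series: a trifluoromethylphenyl ether in place of methoxyphenyl

The compounds below may be only part of what the source reports. "The series", "measured", "known", "first", "only" and "open" are said of these compounds alone.

Measured compounds:
compound 1, `CCCCC(Sc1ccc(OCCCOc2ccccc2OC)cc1)C(=O)O` — > 10000 nM
compound 2, `CCCCC(Sc1ccc(OCCCOc2ccc3ncccc3c2)cc1)C(=O)OCC` — 800 nM

Compound 1 was tested in an assay on isolated protein for inhibition of Polyunsaturated fatty acid 5-lipoxygenase (Homo sapiens), read by HPLC, with a stated time of 15 min, in the presence of a further agent that is not named here; a lower number here means a stronger inhibitor, a higher number a weaker inhibitor. For compound 1 the result is only a limit of the assay, (the limit of > 10000 nM in this assay, at which 1 of the 2 values shown sits), so no number is known for it. Compound 2 differs from compound 1 in several places. In this assay, within the data shown here, compound 2 gives 800 nM; the two values show only that compound 2 lies inside the measured range while compound 1 does not.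

Compound 3, `CCCCC(Sc1ccc(OCCCOc2cccc(C(F)(F)F)c2)cc1)C(=O)O`, has not yet been measured. It differs from compound 1 by 3-(trifluoromethyl)phenyl in place of 2-methoxyphenyl on an oxygen on a saturated carbon. Among the measured compounds shown here, no step between measured compounds bears on this change, so its size cannot be taken from the data. Compound 3 is therefore expected to remain near the limit at which compound 1 sits, and the step of an at least 1.1-fold lower number from compound 1 to compound 3 (0.04 log units; that floor lies within the scatter) is estimated as nothing beyond the scatter. For compound 3 the value is estimated at 9000 nM, between 2500 nM and 30000 nM.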

Compound 3, half-maximal inhibitory concentration: 1600 nM
Beside the measured number, compound 3's estimate is 5.6-fold (0.75 log units) above it; the whole stated range lies above it.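

Compound 3 is the first carboxylic acid shown with a number inside the measured range of this assay, so the group on this oxygen on a saturated carbon can move an acid of this kind into that range. Replacing 2-methoxyphenyl with 3-(trifluoromethyl)phenyl gives an at least 6.2-fold lower number from compound 1 to compound 3 (0.79 log units; beyond the scatter), and that size is only a floor. The result for compound 1 is a limit, and the full size of the step stays unknown because of it: the limit of > 10000 nM in this assay, at which 1 of the 3 values shown sits.

Still open, going by these compounds, is whether the step follows from the trifluoromethyl group, its place on the phenyl ring or the loss of the methoxy group, which a 3-methoxyphenyl or an unsubstituted phenyl here would help to separate. On these data alone, compound 2 differs from compound 3 in more than one place, and the effect of an ethyl ester in place of the carboxylic acid also stays open.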